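Ring size on the amide carbonyl and solubility

The source may hold more compounds than are shown below. What is called first, only, known or untested is meant among the compounds shown, and "the series" means these compounds.

Measured so far in a physicochemical assay for solubility, read by HPLC; on this read-out lower numbers stand for lower solubility and higher numbers for higher solubility:
compound 1 `O=C(C1CC1)N1CCN(c2nc(=O)c3cc(C(F)(F)F)cc([N+](=O)[O-])c3s2)CC1`: 52.9 ug/mL
compound 2 `O=C(C1CCCCC1)N1CCN(c2nc(=O)c3cc(C(F)(F)F)cc([N+](=O)[O-])c3s2)CC1`: 3.24 ug/mL
compound 3 `O=C(C1CCC1)N1CCN(c2nc(=O)c3cc(C(F)(F)F)cc([N+](=O)[O-])c3s2)CC1`: 39.3 ug/mL

Compound 3 stands second highest of the three numbers: its nearest neighbour is compound 1, a 1.3-fold lower number from compound 1 to compound 3 (0.13 log units; within the scatter); furthest is compound 2, a 12-fold higher number from compound 2 to compound 3 (1.08 log units; beyond the scatter).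

Compound 4 `CCC(=O)N1CCN(c2nc(=O)c3cc(C(F)(F)F)cc([N+](=O)[O-])c3s2)CC1` differs from compound 3 by ethyl in place of cyclobutyl on a carbonyl carbon. Among the measured compounds shown here, the steps that bear on it are the contraction of cyclohexyl to cyclobutyl, a 12-fold higher number from compound 2 to compound 3 (1.08 log units; beyond the scatter), and cyclopropyl to cyclobutyl, a 1.3-fold lower number from compound 1 to compound 3 (0.13 log units; within the scatter). Removing two carbons and the ring is expected to give no step beyond the scatter, or a small rise, so for compound 4 the estimated step is a 1.5-fold higher number from compound 3 to compound 4 (0.18 log units; within the scatter). Compound 4 is therefore estimated at 60 ug/mL, within 25 ug/mL to 150 ug/mL.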

Compound 4, solubility: 3.29 ug/mL
For compound 4 the middle estimate is 18-fold (1.26 log units) above the measured one; the measured number lies below the stated range.
By their numbers in this assay, from the lowest: compounds 2 and 4 (each within the scatter of the next); then compounds 3 and 1 (each within the scatter of the next).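

In this assay the change to open-chain ethyl is large, with a 12-fold lower number from compound 3 to compound 4 (1.08 log units; beyond the scatter) and a 16-fold lower number from compound 1 to compound 4 (1.21 log units; beyond the scatter), while a 1.0-fold higher number from compound 2 to compound 4 (0.01 log units; within the scatter) leaves ethyl level with cyclohexyl. On this carbonyl carbon the number therefore does not follow group size: ethyl, with fewer heavy atoms than cyclobutyl, sits with cyclohexyl and apart from cyclopropyl and cyclobutyl. No measurement at hand accounts for this split.

Still open, from the compounds shown here alone, is whether a longer chain such as propyl, or branched isopropyl, stays with ethyl. Also open, going by these compounds, is whether cyclopentyl falls with the small rings or with cyclohexyl.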